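Cytotoxicity on liver cells across benzyl-triazole ethers

The source may hold more compounds than are shown below. What is called first, only, known or untested is meant among the compounds shown, and "the series" means these compounds.

Compound 1 `O=c1ccoc2cc(OCc3cn(Cc4ccc(Cl)cc4)nn3)ccc12` in an ADME assay on L02 cells (Homo sapiens) for cytotoxicity, read by MTT assay, with a stated time of 48 h (a lower number here means a stronger inhibitor, a higher number a weaker inhibitor), gives > 300000 nM, a limit of the assay. Compound 2 `O=c1ccoc2cc(OCc3cn(Cc4cccc(Br)c4)nn3)ccc12` in this assay gives > 300000 nM, also a limit. Compound 3 `O=c1ccoc2cc(OCc3cn(Cc4ccc(Cl)cc4Cl)nn3)ccc12` in this assay gives > 300000 nM, again a limit.

Compound 3 thus stands at the limit shared by all three measured compounds (the limit of > 300000 nM in this assay, at which 3 of the 3 values shown sit). The step to compound 4 `O=c1ccoc2cc(OCc3cn(Cc4cccc(F)c4)nn3)ccc12` is 3-fluorophenyl in place of 2,4-dichlorophenyl on a saturated chain carbon bound to an aromatic nitrogen. Of the measured steps, a step that the two limits leave unreadable from compound 1 to compound 2, a step that the two limits leave unreadable from compound 1 to compound 3 and a step that the two limits leave unreadable from compound 2 to compound 3 are all unreadable because of the limit of > 300000 nM in this assay, at which 3 of the 3 values shown sit; none gives a size. Every benzyl variant so far sits at the limit, so no shift beyond the scatter is expected, and the step that the limit leaves unreadable from compound 3 to compound 4 is an estimate only. Compound 4 is expected to give about 400000 nM, within 100000 nM to 1500000 nM, most likely reported as a limit again.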

Compound 4, half-maximal inhibitory concentration: > 300000 nM
Compound 4: a limit, no number; the forecaster's own chance of this, stated with the estimate: 85%; the middle value does not contradict the limit.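

No step among compound 1, compound 2, compound 3 and compound 4 can be read, because all four values are limits: the limit of > 300000 nM in this assay, at which 4 of the 4 values shown sit.

Still open, going by these compounds, is whether any benzyl variant on the shared core reaches a measurable half-maximal inhibitory concentration in this assay.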